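This account rests on a few compounds, and the source may have more. Where it says the series, first, only, none or still open, it means among the compounds named here.

Compound 1 `COc1ccc(-n2cnnc2-c2cc(OC)c(OC)c(OC)c2)cc1`: 295 nM
Compound 2 `COc1ccc(-n2cnnc2-c2cc(OC)c(OC)c(OC)c2)cc1O`: 933 nM

Going by the values given here, in a functional assay on HCC 2998 cells (Homo sapiens) for inhibition (on this read-out lower numbers stand for stronger inhibition of growth and higher numbers for weaker inhibition of growth), compound 2 gives 933 nM, the higher of the two numbers measured so far. Compound 3 `COc1ccc(-n2cnnc2-c2cc(OC)c(OC)c(OC)c2)cc1F` has fluoro in place of hydroxy on an aromatic carbon, ortho to a methoxy group: fluoro in place of hydroxy on an aromatic carbon. Among the compounds with values here, only one measured step bears on this change: a 3.2-fold higher number from compound 1 to compound 2 (0.50 log units; beyond the scatter). It came with hydroxy in place of hydrogen on that same aromatic carbon. Within the data shown here, no measured compound carries the fluoro group, so this comparison is indirect. Compound 1, which lacks the hydroxy, stands at 295 nM, so a modest step toward a lower number is expected, similar in size to the measured one or somewhat smaller. The estimated change is a 2.3-fold lower number from compound 2 to compound 3 (0.37 log units; beyond the scatter). For compound 3 the estimated value is 400 nM, with an expected range from 130 nM to 1100 nM.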

Compound 3, concentration for 50% growth inhibition: 631 nM
Estimate against measurement, compound 3: 1.6-fold (0.20 log units) below; measured number inside the range.
By their numbers in this assay, from the lowest: compound 1; then compounds 3 and 2 (each within the scatter of the next).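

In this assay, fluoro in place of hydroxy on this aromatic carbon gives a 1.5-fold lower number from compound 2 to compound 3 (0.17 log units; within the scatter), so the two groups cannot be told apart here, even though the hydrogen-bond donor of the hydroxy is gone in compound 3. Set against hydrogen, fluoro gives a 2.1-fold higher number from compound 1 to compound 3 (0.33 log units; beyond the scatter), which is beyond the scatter and shows that among these three compounds both substituents at this place, ortho to a methoxy group, stand on the weaker side of compound 1, with none going against this. Nothing at hand explains why either group gives a higher number than hydrogen.

As far as these compounds go, whether this holds for an amine, a chloro group or a longer ether chain on the same carbon remains open. The compounds shown also leave open whether any group at this place could match or improve on hydrogen.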